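Benzyl on the ring oxygen: an untested step

The source may hold more compounds than are shown below. What is called first, only, known or untested is meant among the compounds shown, and "the series" means these compounds.

The series shares the core of compound 1 `NCC(N)CCCNC(=O)CCn1cccc(O)c1=O`, which in a physicochemical assay, read by spectrophotometry, with a stated time of 10 min, tested at 0.05 mM, in the presence of a further agent that is not named here (on this read-out lower numbers stand for a weaker effect and higher numbers for a stronger effect at the one concentration tested), gives 24.8%. Compound 2 `NCC(N)CCCCNC(=O)CCn1cccc(O)c1=O` gives 24.5%, and compound 3 `Cc1c(O)c(=O)ccn1CCCNC(=O)CCC(N)CN` gives 24.7%. Among the compounds with values here, the only step with a single difference, a number 0.3 percentage points lower from compound 1 to compound 2 (within the scatter), is within the scatter, and compound 2 and compound 3 likewise show numbers within the scatter of each other, so compound 2 stands level with both on these figures. Compound 4 `NCC(N)CCCCNC(=O)CCn1cccc(OCc2ccccc2)c1=O` differs from compound 2 by benzyl in place of hydrogen on an oxygen on an aromatic ring. Within the data shown here, no measured step touches that position: the one step available alters the diamine chain only, and it was within the scatter. For the new change there is therefore no measured guide, and any expectation rests on the change sitting at a place not yet varied in this set. On that footing a step of a number 14.5 percentage points lower from compound 2 to compound 4 (beyond the scatter) is expected only tentatively, with a wide range. Compound 4 is estimated at 10%, between 0% and 25%.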

Compound 4, a percentage reported as activity, at one concentration (the size of the read-out at that concentration, not a potency): 12.1%
Beside the measured number, compound 4's estimate is 2.1 percentage points below it, within the range that was stated.
By their numbers in this assay, from the lowest: compound 4; then compounds 2, 3 and 1 (each within the scatter of the next).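

In this assay, within the data shown here, the change from hydroxy to benzyloxy gives a number 12.4 percentage points lower from compound 2 to compound 4 (beyond the scatter) and so is the first single change to exceed the scatter, the earlier step in the diamine chain having stayed within it. The read-out therefore responds to substitution at this oxygen on the aromatic ring, yet a hydrogen on that oxygen is not required for a measurable reading: compound 4 still gives 12.1% at the one concentration tested. Nothing available bears on why the number falls at this position.

With benzyl as the only group shown on this oxygen, the effect of losing the hydrogen cannot be separated from that of adding the benzyl group. A methyl group on the same oxygen, or a phenethyl group in place of benzyl, would help to separate the two.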